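Extending the Ring Amine: Predicting Compound 4 in HT-29 Cells

The source may hold more compounds than are shown below. What is called first, only, known or untested is meant among the compounds shown, and "the series" means these compounds.

Measured compounds:
compound 1 `Cn1cnnc1SCC(=O)Nc1ccc(-c2nc(-c3ccccc3)c(-c3ccccc3)n2C)cc1`, 88%
compound 2 `Cn1nnnc1SCC(=O)Nc1ccc(-c2nc(-c3ccccc3)c(-c3ccccc3)n2C)cc1`, 89%
compound 3 `CN1CCN(CC(=O)Nc2ccc(-c3nc(-c4ccccc4)c(-c4ccccc4)n3C)cc2)CC1`, 53.1%

In a functional assay on HT-29 cells (Homo sapiens) for cytotoxicity, read by MTT assay, with a stated time of 24 h, tested at 80 ug/mL (a lower number here means a weaker effect, a higher number a stronger effect of the compound at the concentration tested), compound 3 stands lowest of the three measured compounds. Compound 1 and compound 2 differ only in the ring on the sulfur, and the step of a number 1 percentage points higher from compound 1 to compound 2 (within the scatter) is within the scatter. Replacing that sulfur-linked ring by the ring amine of compound 3 costs much more: a number 34.9 percentage points lower from compound 1 to compound 3 (beyond the scatter) and a number 35.9 percentage points lower from compound 2 to compound 3 (beyond the scatter) are both large drops.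

Compound 4 `Cc1ccc(CN2CCN(CC(=O)Nc3ccc(-c4nc(-c5ccccc5)c(-c5ccccc5)n4C)cc3)CC2)cc1` keeps the ring amine of compound 3 and adds a group to it: 4-methylphenyl in place of hydrogen on a saturated chain carbon bound to an amine nitrogen in a ring.

For the measured compounds named here, no measured step adds a group at this place, so there is no direct precedent. The two large steps to compound 3 show only that what sits on this chain carbon matters a great deal; they do not say in which direction a 4-methylphenyl group will move the number. The expectation therefore stays close to compound 3, with a wide range, and a modest rise is allowed for: the estimated step is a number 6.9 percentage points higher from compound 3 to compound 4 (within the scatter). Compound 4 is estimated at 60%, within 38% to 82%.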

Compound 4, a percentage reported as activity, at one concentration (the size of the read-out at that concentration, not a potency): 54.2%
Compound 4: middle estimate off by 5.8 percentage points, on the high side; the measured number falls inside the stated range.
By their numbers in this assay, from the lowest: compounds 3 and 4 (each within the scatter of the next); then compounds 1 and 2 (each within the scatter of the next).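

In this assay, the first measured addition at this place gives a number 1.1 percentage points higher from compound 3 to compound 4 (within the scatter), so 4-methylphenyl in place of hydrogen on a saturated chain carbon bound to an amine nitrogen in a ring leaves the two compounds indistinguishable in this read-out. This is informative given the size of the change: the same difference, cut one bond further out, is methyl to 4-methylbenzyl, and it brings 7 heavy atoms and a six-membered aromatic ring, yet this single example gives no sign that the read-out responds to what is added here, unlike the large steps seen when the whole sulfur-linked ring gave way to the ring amine. No available evidence explains why the addition makes so little difference.

The compounds shown leave open whether this holds for other groups at the same place, such as a benzyl group carrying a carboxylic acid or an amine, or a longer chain between the ring amine and the 4-methylphenyl. A read-out at one concentration also leaves open whether compound 3 and compound 4 would stay together across a range of concentrations.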